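Bis-sulfonamide piperidine esters: a sulfamoyl amine swap

The source may report more compounds than this note shows. Statements on the series, on what has been measured and on what is new or still open speak of the compounds shown alone.

Measured compounds:
- Compound 1 `CCCN(CCC)S(=O)(=O)c1ccc(S(=O)(=O)N2CCC[C@@H](C(=O)OCC)C2)cc1`: in a functional assay on MIA PaCa-2 cells (Homo sapiens) for inhibition, read by MTT assay, with a stated time of 3 days (on this read-out lower numbers stand for stronger inhibition and higher numbers for weaker inhibition), compound 1 gives > 10000 nM, which is a limit of the assay and not a number.
- Compound 2 `CCOC(=O)C1CCCCN1S(=O)(=O)c1ccc(S(=O)(=O)N(CC)CC)cc1`: in this assay compound 2 gives > 10000 nM, again a limit.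
- Compound 3 `CCN(CC)S(=O)(=O)c1ccc(S(=O)(=O)N2CCC[C@@H](C(=O)N3CCN(C(=O)OC(C)(C)C)CC3)C2)cc1`: in this assay compound 3 gives > 10000 nM, also a limit.

Within the data shown here, compound 1 therefore stands nowhere in particular on these numbers: it sits at the limit of > 10000 nM in this assay, at which 3 of the 3 values shown sit, alongside the two other measured compounds, and no measured compound in this set gives a number at all. Among the measured compounds shown here, no pair among the measured compounds differs in only one place, so no single step has been quantified.

The compound not yet measured is compound 4 `CCOC(=O)[C@@H]1CCCN(S(=O)(=O)c2ccc(S(=O)(=O)N(CC)C(C)C)cc2)C1`. It differs from compound 1 by ethyl(isopropyl)amino in place of dipropylamino on a sulfonyl sulfur. Both groups are acyclic, carry no donors or acceptors, and bear no charge. Given that every measured compound, including compound 1, lies at the limit, the expectation for compound 4 is a step of no size beyond the scatter, a step that the limit leaves unreadable from compound 1 to compound 4, most likely again reported as a limit. Compound 4 is estimated at 15000 nM, with a range from 5000 nM to 50000 nM.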

Compound 4, half-maximal inhibitory concentration: > 10000 nM
Compound 4: only a limit was reported; the forecaster's own chance of this, stated with the estimate: 85%; the middle value is on the limit's open side.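

Among these compounds, compound 1 and compound 4 both stand only at a limit in this assay, so ethyl(isopropyl)amino in place of dipropylamino on a sulfonyl sulfur gives no step that can be read. The compounds shown leave open which structure, if any, would give an actual number in this assay, as every result so far is a limit: the limit of > 10000 nM in this assay, at which 4 of the 4 values shown sit.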